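A thiophene swap from compound 3 to compound 4

This account rests on a few compounds, and the source may have more. Where it says the series, first, only, none or still open, it means among the compounds named here.

Compound 1 `N=C(N)N/N=C/c1c(-c2cc(Cl)sc2Cl)nc2n1CCS2`: 8130 nM
Compound 2 `N=C(N)N/N=C/c1c(-c2ccsc2)nc2n1CCS2`: 17400 nM
Compound 3 `Cc1cc(-c2nc3n(c2/C=N/NC(=N)N)CCS3)c(C)s1`: 15500 nM

In a functional assay on cells (Cancer cell lines, Homo sapiens) for inhibition (on this read-out lower numbers stand for stronger inhibition of growth and higher numbers for weaker inhibition of growth), compound 3 gives 15500 nM, which lies within the usual scatter of both other measured compounds. Compound 4 `N=C(N)N/N=C/c1c(-c2cccs2)nc2n1CCS2` has not yet been measured. It carries thiophen-2-yl in place of 2,5-dimethylthiophen-3-yl on an aromatic carbon. Within the data shown here, no measured compound carries thiophen-2-yl, so the evidence is indirect.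

The three measured compounds differ only in the thiophene group, and those swaps changed the number little. The largest was a 2.1-fold higher number from compound 1 to compound 2 (0.33 log units; beyond the scatter), and it was modest. The others were a 1.9-fold higher number from compound 1 to compound 3 (0.28 log units; within the scatter) and a 1.1-fold lower number from compound 2 to compound 3 (0.05 log units; within the scatter), and the last of these is the closest comparison, since it also concerns the dimethyl groups. No step beyond the scatter is therefore expected in this assay, in either direction. The estimated change is a 1.0-fold higher number from compound 3 to compound 4 (0.01 log units; within the scatter). Compound 4 is expected at 16000 nM, with an estimated range from 8000 nM to 32000 nM.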

Compound 4, concentration for 50% growth inhibition: 19500 nM
Beside the measured number, compound 4's estimate is 1.2-fold (0.09 log units) below it, and the stated range covers the measured number.
By their numbers in this assay, from the lowest: compounds 1, 3, 2 and 4 (each within the scatter of the next, the first and the last beyond it).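

In this assay, the point of attachment of the thiophene makes no readable difference: thiophen-2-yl in place of thiophen-3-yl gives a 1.1-fold higher number from compound 2 to compound 4 (0.05 log units; within the scatter). Thiophen-2-yl in place of 2,5-dimethylthiophen-3-yl also stays within the scatter, with a 1.3-fold higher number from compound 3 to compound 4 (0.10 log units; within the scatter), so compound 4 extends the flat picture among the thiophenes without chlorine. Among these compounds, only against the 2,5-dichlorothiophen-3-yl group does the new group stand apart, with a 2.4-fold higher number from compound 1 to compound 4 (0.38 log units; beyond the scatter), a modest step that matches the one already seen for compound 2 but not the one for compound 3.

Nothing in the data explains these small differences. From the compounds shown here alone, all four compounds carry a thiophene at this position, so it remains open how a plain phenyl ring, a pyridine, an amine or a carboxylic acid there would affect growth inhibition.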